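The source may report more compounds than this note shows. Statements on the series, on what has been measured and on what is new or still open speak of the compounds shown alone.

Measured compounds:
compound 1 `COc1ccc(-c2[nH]c3ccccc3c2/C=C(\C#N)S(=O)(=O)c2ccccc2)cc1` — 578 nM
compound 2 `CCOC(=O)C(=Cc1c(-c2ccccc2)[nH]c2ccccc12)C(=O)OCC` — 10500 nM
compound 3 `CC(=O)/C(=C\c1c(-c2ccccc2)[nH]c2ccccc12)S(=O)(=O)c1ccccc1` — 3700 nM

All three were read in a functional assay on OVCAR-4 cells (Homo sapiens) for inhibition, read by sulforhodamine B assay, with a stated time of 48 h; on this read-out lower numbers stand for stronger inhibition of growth and higher numbers for weaker inhibition of growth. Compound 1 gives 578 nM and compound 2 gives 10500 nM. Compound 3, at 3700 nM, stands second highest of the three, nearer to compound 2 than to compound 1; both gaps lie beyond the scatter. No pair among these three differs in one place only, so no single step is shown.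

Compound 4 `O=C(/C(=C\c1c(-c2ccccc2)[nH]c2ccccc12)S(=O)(=O)c1ccccc1)c1ccccc1` is not yet measured. It differs from compound 3 by phenyl in place of methyl on a carbonyl carbon; the shared core and the sulfonyl group are kept. No measured pair shows this change, so its direction rests on no shown step. For compound 4 a modest move towards a lower number is expected, the step of a 1.5-fold lower number from compound 3 to compound 4 (0.17 log units; within the scatter) being estimated to sit near the edge of the scatter. Compound 4 is estimated at 2500 nM, with a range from 700 nM to 9000 nM.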

Compound 4, concentration for 50% growth inhibition: 6600 nM
Compound 4: the middle estimate sits 2.6-fold (0.42 log units) below what was measured, and the stated range covers the measured number.
By their numbers in this assay, from the lowest: compound 1; then compounds 3, 4 and 2 (each within the scatter of the next, the first and the last beyond it).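

In this assay, the exchange of acetyl for benzoyl gives a 1.8-fold higher number from compound 3 to compound 4 (0.25 log units; within the scatter), the first single-place step shown in the series. This position on the carbonyl carbon therefore accepts phenyl in place of methyl without a shift beyond the scatter, so the added aromatic ring leaves growth inhibition unresolved from that of compound 3. No measured evidence here explains the size of this step.

On these data alone, whether an amine or a longer chain on the same carbonyl carbon would shift the number beyond the scatter remains open. A single step also cannot show whether this tolerance holds on other cores in the series.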